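Amine variation at the chain end of the stilbene ether series

The compounds below may be only part of what the source reports. "The series", "measured", "known", "first", "only" and "open" are said of these compounds alone.

Compound 1 `CCCN(CCC)CCCCOc1ccccc1/C=C/c1ccccc1` gives 0% in a functional assay on the whole organism with Mus musculus as the target, in the maximal electroshock model, at a dose of 50 mg/kg by the oral route; a higher number here means more inhibition at the dose given (going by the name of the read-out), a lower number less inhibition. Compound 2 `C(=C/c1ccccc1OCCCCN1CCCC1)\c1ccccc1` gives 42.9%; compound 3 `OC1CCN(CCCCOc2ccccc2/C=C/c2ccccc2)CC1` gives 0%. On these numbers compound 3 stands level with compound 1, the two together being the lowest of the three, with compound 2 the only one higher: no change at the digits printed from compound 1 to compound 3 (within the scatter), and a number 42.9 percentage points lower from compound 2 to compound 3 (beyond the scatter).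

Compound 4 `CCN1CCN(CCCCOc2ccccc2/C=C/c2ccccc2)CC1` differs from compound 3 as follows: 4-ethylpiperazin-1-yl in place of 4-hydroxypiperidin-1-yl on a saturated chain carbon, four bonds along the chain from an oxygen on an aromatic ring.

Going by the values given here, the steps that bear on this are a number 42.9 percentage points higher from compound 1 to compound 2 (beyond the scatter) and a number 42.9 percentage points lower from compound 2 to compound 3 (beyond the scatter), both large, while no change at the digits printed from compound 1 to compound 3 (within the scatter) shows the two amines without a small ring falling together. Among the compounds with values here, no measured step covers a second ring nitrogen or the loss of the hydroxyl group. Compound 4 is therefore expected to move only modestly upward, a number 15 percentage points higher from compound 3 to compound 4 (beyond the scatter), well short of compound 2 because of the inhibition of compound 3 at 0%. The estimate for compound 4 is 15%, with a range from 0% to 45%.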

Compound 4, a percentage reported as inhibition, in the whole organism at one dose (the size of the read-out at that dose, not a potency): 33.3%
Estimate against measurement, compound 4: 18.3 percentage points below; low and high end bracket the measured number.
By their numbers in this assay, from the lowest: compounds 1 and 3 (each within the scatter of the next); then compounds 4 and 2 (each within the scatter of the next).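

In this assay, the place on a saturated chain carbon, four bonds along the chain from an oxygen on an aromatic ring, is not limited to pyrrolidin-1-yl: 4-ethylpiperazin-1-yl gives a number 33.3 percentage points higher from compound 3 to compound 4 (beyond the scatter) and a number 33.3 percentage points higher from compound 1 to compound 4 (beyond the scatter). Six-membered ring amines therefore do not fall together, as compound 3 stays at the low end while the 4-ethylpiperazin-1-yl group gives a number 9.6 percentage points lower from compound 2 to compound 4 (within the scatter). Nothing on hand accounts for these steps, and the second ring nitrogen, the ethyl group and the loss of the hydroxyl cannot be told apart.

Open, from the compounds shown here alone, is how plain piperidin-1-yl, piperazin-1-yl without the ethyl group, or morpholin-4-yl would read in this assay. Also open, going by these compounds, is whether the 4-ethylpiperazin-1-yl result holds with a shorter or longer chain between the oxygen and the amine.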